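Plasma protein binding: 2-methoxyphenyl in place of 2,5-difluorophenyl

The source may hold more compounds than are shown below. What is called first, only, known or untested is meant among the compounds shown, and "the series" means these compounds.

- Compound 1 (`OC[C@@H]1[C@@H](O)[C@H](O)[C@@H](O)CN1CCCCCCOc1cc(F)ccc1F`) gives 74% as measured
- Compound 2 (`OC[C@@H]1[C@@H](O)[C@H](O)[C@@H](O)CN1CCCCCCOc1cccc(C(F)(F)F)c1`) gives 93% as measured
- Compound 3 (`COc1ccccc1OCCCCCCN1C[C@H](O)[C@@H](O)[C@H](O)[C@H]1CO`) is not yet measured

For the measured compounds named here, in an ADME assay on a cell-free system (plasma, Homo sapiens) for protein binding, compound 1 gives 74% and compound 2 gives 93% as the only two values so far. Compound 1 therefore has the higher unbound fraction of the pair, and the gap lies beyond the scatter.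

Compound 3 carries 2-methoxyphenyl in place of 2,5-difluorophenyl on an oxygen on a saturated carbon. Going by the values given here, no measured pair isolates a change of this kind, so the data offer no direct guide. No shift beyond the scatter is expected in this assay and no firm direction can be assigned. The estimated a 1.1-fold higher unbound fraction from compound 1 to compound 3 (0.03 log units; within the scatter) is expected to stay within the scatter. Compound 3 is expected at 72% (estimated range 55% to 86%).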

Compound 3, plasma protein binding in the plasma assay: 65%
Beside the measured number, compound 3's estimate is 1.3-fold (0.10 log units) (unbound fraction) below it, within the range that was stated.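

For the compounds shown here, in the plasma assay, compound 1 gives 74% and compound 3 gives 65%, and replacing 2,5-difluorophenyl with 2-methoxyphenyl on an oxygen on a saturated carbon gives a 1.3-fold higher unbound fraction from compound 1 to compound 3 (0.13 log units; within the scatter), the first step at this position that changes one place only, and the position accepts this exchange with no shift beyond the scatter. In a physicochemical assay for solubility, in phosphate buffer, at pH 7.4 (a lower number here means a less soluble compound, a higher number a more soluble compound), compound 1 gives 292000 nM and compound 3 gives 293000 nM, and the same change gives a 1.0-fold higher number from compound 1 to compound 3 (0.00 log units; within the scatter), so this pair of groups is not told apart by either read-out. Nothing measured here accounts for either result.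

This single step leaves open whether any change at this position can move plasma protein binding beyond the scatter while the rest of the molecule stays fixed. An aryl group carrying an amine or a carboxylic acid, or a longer chain between the ring oxygen and the core, would test how far this tolerance extends.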